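Compound 1 to compound 4: aryl swap, stability outlook

The source may report more compounds than this note shows. Statements on the series, on what has been measured and on what is new or still open speak of the compounds shown alone.

Within the data shown here, in an ADME assay on microsomes from liver (Rattus norvegicus) for metabolic stability, read by LC-MS, using NADPH, at 37 degrees C (on this read-out higher numbers stand for a longer-lived compound and lower numbers for a shorter-lived compound), compound 1 `Cc1ccc(C)c(-c2nc(CN3CCC(C(=O)NCCCN4C[C@H](C)C[C@H](C)C4)CC3)c(C)o2)c1` gives 0.5 h, the highest of the three numbers measured so far. Compound 2 `CC[C@@H]1C[C@H](CC)CN(CCCNC(=O)C2CCN(Cc3nc(-c4ccccc4C)oc3C)CC2)C1` gives 0.0917 h and compound 3 `Cc1cccc(Cl)c1-c1nc(CN2CCC(C(=O)NCCCN3CCC(C(C)C)CC3)CC2)c(C)o1` gives 0.0333 h; both steps down from compound 1 lie beyond the scatter, with compound 3 the furthest. Compound 4 `COc1cccc(Cl)c1-c1nc(CN2CCC(C(=O)NCCCN3C[C@H](C)C[C@H](C)C3)CC2)c(C)o1` is not yet measured and differs from compound 1 in one place: 2-chloro-6-methoxyphenyl in place of 2,5-dimethylphenyl on an aromatic carbon. Among the measured compounds shown here, no measured pair isolates this change. For the measured compounds named here, compound 3, the only other compound with chlorine in its aryl group but differing elsewhere too, gives 0.0333 h, so a step below compound 1 is expected, its size uncertain. The step from compound 1 to compound 4 is expected at a 2.5-fold lower number from compound 1 to compound 4 (0.40 log units; beyond the scatter). For compound 4 the expected value is 0.2 h, ranging from 0.05 h to 0.6 h.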

Compound 4, half-life: 0.055 h
Estimate against measurement, compound 4: 3.6-fold (0.56 log units) above; low and high end bracket the measured number.
By their numbers in this assay, from the lowest: compounds 3, 4 and 2 (each within the scatter of the next, the first and the last beyond it); then compound 1.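

In this assay, the aromatic carbon bearing the aryl group is sensitive to this change: with the rest of compound 1 held constant, 2-chloro-6-methoxyphenyl in place of 2,5-dimethylphenyl gives a 9.1-fold lower number from compound 1 to compound 4 (0.96 log units; beyond the scatter) and removes the lead that compound 1 held. Among these compounds, this is the only step in the set that isolates the aryl group. No supporting evidence bears on the cause of this step.

Open, as far as these compounds go, is whether the chlorine or the methoxy accounts for the step, and how a plain phenyl or a pyridyl group on this aromatic carbon would read.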